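Half-life expectation for an aryl swap

The source may hold more compounds than are shown below. What is called first, only, known or untested is meant among the compounds shown, and "the series" means these compounds.

In an ADME assay on microsomes from liver (Mus musculus) for metabolic stability, read by LC-MS, using NADPH, tested at 4.6 uM (a higher number here means that the compound lasts longer, a lower number that the compound disappears faster), compound 1 `CCCCCNC(=O)n1cc(-c2ccccc2)oc1=O` gives < 0.0834 h as a limit. Compound 2 `CCOCCNC(=O)n1cc(-c2ccccc2)oc1=O` gives < 0.0834 h as a limit too. The pair yields a step that the two limits leave unreadable from compound 1 to compound 2 and so no size to carry forward. Compound 3 `COc1cc(-c2cn(C(=O)NCCCCc3ccccc3)c(=O)o2)ccc1F` gives > 1 h as a limit, the only one of the three at the long-lived end. Compound 4 `O=C(NCCCCc1ccccc1)n1cc(-c2ccncc2)oc1=O` carries pyridin-4-yl in place of 4-fluoro-3-methoxyphenyl on an aromatic carbon as its change: pyridin-4-yl in place of 4-fluoro-3-methoxyphenyl on an aromatic carbon. Among the compounds with values here, no measured step covers this change, so the direction is only a cautious expectation: a shorter half-life in this assay than for compound 3. The estimated move is an at least 2.0-fold lower number from compound 3 to compound 4 (0.30 log units; that floor lies within the scatter) with wide uncertainty. Compound 4 is expected at 0.5 h within an estimated range of 0.12 h to 1.5 h in this reading.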

Compound 4, half-life: > 1 h
Compound 4 was reported as a limit; the forecaster's own chance of this, stated with the estimate: 35%; at least 2.0-fold (0.30 log units) between middle value and limit.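

In this assay compound 3 stands as a limit at > 1 h. Compound 4 is also a limit, at > 1 h, so no step can be read for this pair. Still open, as far as these compounds go, is whether pyridin-4-yl in place of 4-fluoro-3-methoxyphenyl changes the half-life at all.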